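A few compounds are considered here, and "the series" means these few. Any claim that something is new, unique, unknown or untested is made for them only; others in the source may bear on it.

Compound 1 `COc1ccc(/C=C2\CN(C(=S)SCc3cn(Cc4ccccc4F)nn3)C/C(=C\c3ccc(OC)cc3)C2=O)cc1`: in a functional assay on PC-3 cells (Homo sapiens) for cytotoxicity, read by MTT assay, with a stated time of 24 h (on this read-out higher numbers stand for weaker inhibition and lower numbers for stronger inhibition), compound 1 gives 31500 nM.
Compound 2 `COc1ccc(/C=C2\CN(C(=S)SCc3cn(Cc4cccc(Cl)c4)nn3)C/C(=C\c3ccc(OC)cc3)C2=O)cc1`: in this assay compound 2 reaches only the limit > 80000 nM, which is a limit of the assay rather than a number (the limit of > 80000 nM in this assay, at which 1 of the 3 values shown sits).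
Compound 3 `Cc1ccc(/C=C2\CN(Cc3cn(Cc4cccc(Cl)c4)nn3)C/C(=C\c3ccc(C)cc3)C2=O)cc1`: in this assay compound 3 gives 29300 nM.

The change from compound 2 to compound 1 is 2-fluorophenyl in place of 3-chlorophenyl on a saturated chain carbon bound to an aromatic nitrogen and it made a step of an at least 2.5-fold lower number from compound 2 to compound 1 (0.40 log units; beyond the scatter). The cores of compound 3 and compound 2 differ too, but that difference is not broken down here. Compound 4 `Cc1ccc(/C=C2\CN(Cc3cn(Cc4ccccc4F)nn3)C/C(=C\c3ccc(C)cc3)C2=O)cc1` carries the same change relative to compound 3, namely (2-fluorophenyl in place of 3-chlorophenyl on a saturated chain carbon bound to an aromatic nitrogen), at the same place. The step from compound 3 to compound 4 in this assay is expected to be about a 1.5-fold lower number from compound 3 to compound 4 (0.17 log units; within the scatter), resting on the step from compound 2 to compound 1 an at least 2.5-fold lower number from compound 2 to compound 1 (0.40 log units; beyond the scatter), though that step was measured from a limit and the cores differ. Compound 4 is therefore estimated at 20000 nM, between 8000 nM and 55000 nM.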

Compound 4, half-maximal inhibitory concentration: 8800 nM
For compound 4 the middle estimate is 2.3-fold (0.36 log units) above the measured one, and the stated range covers the measured number.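

In this assay the swap from 3-chlorobenzyl to 2-fluorobenzyl gives a 3.3-fold lower number from compound 3 to compound 4 (0.52 log units; beyond the scatter). The number falls on both cores, so in these two pairs the direction of the change carries over from one core to the other. Whether its size carries over as well cannot be said, since one end of the earlier step is a limit of the assay rather than a number: the same change on two cores in this assay, an at least 2.5-fold lower number (0.40 log units; beyond the scatter) from compound 2 to compound 1 and a 3.3-fold lower number (0.52 log units; beyond the scatter) from compound 3 to compound 4; the limit leaves it open whether they differ.

Two pairs on two cores also say nothing about how the change behaves on any further core. Still open, as far as these compounds go, is what a 2-chlorobenzyl or 3-fluorobenzyl group would give, which could separate the change of halogen from the change of its place on the ring, and how an unsubstituted benzyl group would compare.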